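This account rests on a few compounds, and the source may have more. Where it says the series, first, only, none or still open, it means among the compounds named here.

Measured in an ADME assay on microsomes from liver (Mus musculus) for metabolic stability, read by LC-MS, with a stated time of 1 h, tested at 5 uM; on this read-out lower numbers stand for a less stable compound and higher numbers for a more stable compound:
Compound 1 `Cc1nc(-c2ccccc2)c(C(=O)N2CCN(c3cccc(Cl)c3)CC2)o1`: 2%
Compound 2 `Cc1nc(-c2ccccc2F)c(C(=O)N2CCN(c3cc(Cl)cc(Cl)c3)CC2)o1`: 49%

Of these two numbers, compound 1 stands lowest at 2%, while compound 2 lies higher at 49%, a gap beyond the usual scatter. The two compounds differ in more than one place, so their gap does not isolate any single change. Compound 3 `Cc1cc(C)cc(N2CCN(C(=O)c3oc(C)nc3-c3ccccc3)CC2)c1` has not yet been measured. It carries 3,5-dimethylphenyl in place of 3-chlorophenyl on an amine nitrogen in a ring. Going by the values given here, no measured step speaks to this change directly, so the expectation in this assay is for no step beyond the scatter, with any movement more likely upward, since compound 1 at 2% has little room to fall. The expected change is a number 4 percentage points higher from compound 1 to compound 3 (within the scatter). Compound 3 is estimated at 6%, with an expected range of 0% to 22%.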

Compound 3, percent of the compound remaining: 12%
Compound 3: middle estimate off by 6 percentage points, on the low side, within the range that was stated.
By their numbers in this assay, from the lowest: compounds 1 and 3 (each within the scatter of the next); then compound 2.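

Going by these compounds alone, exchanging 3-chlorophenyl for 3,5-dimethylphenyl on the amine nitrogen in the ring gives the first step that can be read at this position: in this assay, it is a number 10 percentage points higher from compound 1 to compound 3 (within the scatter). On the core of compound 1, this one exchange therefore does not separate the two compounds on this read-out, and it gives no sign that this position alone governs the number. Nothing available offers an explanation for this result.

The compounds shown leave open how much of the number for compound 2 belongs to its 3,5-dichlorophenyl and how much to the fluorine on its other phenyl ring. They also leave open how the same position responds to a methoxy group or a nitrile on the phenyl ring, or to a pyridine in place of that ring.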